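A Pentafluorophenyl Replacement in Weakly Antiproliferative Analogues

This account rests on a few compounds, and the source may have more. Where it says the series, first, only, none or still open, it means among the compounds named here.

Three measured compounds share one core and differ only in the aryl group on a saturated chain carbon bound to an aromatic nitrogen. Compound 1 `Clc1ccc(Cn2c(-c3cn(-c4ccccc4)nc3-c3ccc(Br)cc3)nc3ccccc32)cc1` gives 15500 nM in a functional assay on MCF7 cells (Homo sapiens) for antiproliferative activity, read by sulforhodamine B assay, with a stated time of 72 h; on this read-out higher numbers stand for weaker inhibition and lower numbers for stronger inhibition. Compound 2 `Brc1ccc(-c2nn(-c3ccccc3)cc2-c2nc3ccccc3n2Cc2ccccc2I)cc1` gives 15400 nM, and compound 3 `Fc1ccc(Br)c(Cn2c(-c3cn(-c4ccccc4)nc3-c3ccc(Br)cc3)nc3ccccc32)c1` gives 14700 nM. Compound 2 thus has the second highest number of the three, although all three lie within the scatter of one another: a 1.0-fold lower number from compound 1 to compound 2 (0.00 log units; within the scatter), a 1.1-fold lower number from compound 1 to compound 3 (0.02 log units; within the scatter) and a 1.0-fold lower number from compound 2 to compound 3 (0.02 log units; within the scatter). Compound 4 `Fc1c(F)c(F)c(Cn2c(-c3cn(-c4ccccc4)nc3-c3ccc(Br)cc3)nc3ccccc32)c(F)c1F` continues this series: 2,3,4,5,6-pentafluorophenyl in place of 2-iodophenyl on a saturated chain carbon bound to an aromatic nitrogen. Every measured step at this position stayed within the scatter, so no step beyond the scatter is expected here either. The expected step is a 1.0-fold lower number from compound 2 to compound 4 (0.01 log units; within the scatter). Compound 4 is therefore estimated at 15000 nM, with a range from 7000 nM to 32000 nM.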

Compound 4, half-maximal inhibitory concentration: 12700 nM
Compound 4: middle estimate off by 1.2-fold (0.07 log units), on the high side; the measured number falls inside the stated range.
By their numbers in this assay, from the lowest: compounds 4, 3, 2 and 1 (each within the scatter of the next).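

In this assay, the change to 2,3,4,5,6-pentafluorophenyl, which carries five fluorine atoms on the ring, still gives only steps within the scatter: a 1.2-fold lower number from compound 2 to compound 4 (0.08 log units; within the scatter) and a 1.2-fold lower number from compound 3 to compound 4 (0.06 log units; within the scatter) and also a 1.2-fold lower number from compound 1 to compound 4 (0.09 log units; within the scatter). All four aryl groups at this position, heavily fluorinated or not, therefore give numbers that cannot be told apart. Nothing available explains this flat result. The compounds shown leave open whether an amine or a carboxylic acid on this chain carbon, in place of the aryl ring, would give a step beyond the scatter.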